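Shortening the iodoacetamide linker on a triphosphate scaffold

The source may report more compounds than this note shows. Statements on the series, on what has been measured and on what is new or still open speak of the compounds shown alone.

Three purine triphosphates carrying a terminal iodoacetamide have been examined in an assay on isolated protein for inhibition of hexokinase-2 (Rattus norvegicus), with a stated time of 6 h, tested at 10 mM; on this read-out lower numbers stand for less inhibition and higher numbers for more inhibition at the one concentration tested (going by the name of the read-out). Compound 1 `O=C(CI)NCCCCC(=O)NCCCCCCNc1ncnc2c1ncn2[C@@H]1O[C@H](COP(=O)(O)OP(=O)(O)OP(=O)(O)O)[C@@H](O)[C@H]1O` gives 0% in this assay. Compound 2 `Nc1ncnc2c1nc(NCCCCNC(=O)CI)n2[C@@H]1O[C@H](COP(=O)(O)OP(=O)(O)OP(=O)(O)O)[C@@H](O)[C@H]1O` gives 0% in this assay, and compound 3 `CN(CCCN(C)C(=O)CCCCNc1ncnc2c1ncn2[C@@H]1O[C@H](COP(=O)(O)OP(=O)(O)OP(=O)(O)O)[C@@H](O)[C@H]1O)C(=O)CCCCNC(=O)CI` gives 0% in this assay. Within the data shown here, on these numbers compound 1 stands level with compound 2 and with compound 3, both within the usual scatter, so no order among the three can be read from the data, and no step between any two of them has been worked out.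

Compound 4 `O=C(CI)NCCCCCCCNc1ncnc2c1ncn2[C@@H]1O[C@H](COP(=O)(O)OP(=O)(O)OP(=O)(O)O)[C@@H](O)[C@H]1O` is the next member of the set. It differs from compound 1 in one place, (a group of 6 heavy atoms (3 carbon, 1 nitrogen, 1 oxygen, 1 iodine; no ring) in place of a group of 12 heavy atoms (7 carbon, 2 nitrogen, 2 oxygen, 1 iodine; no ring), on a saturated chain carbon, six bonds along the chain from a nitrogen on an aromatic ring), so that the chain between the amino group on the core and the iodoacetamide end is shorter in compound 4 than in compound 1. Since every measured compound sits at the same reading in this assay, there is no trend on which a rise or a fall could rest. The step expected from compound 1 to compound 4 is therefore no change at the digits printed from compound 1 to compound 4 (within the scatter), that is, none beyond the scatter. For compound 4 the estimated value in this assay is 0%, with an expected range from 0% to 10%.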

Compound 4, a percentage reported as inhibition, at one concentration (the size of the read-out at that concentration, not a potency): 30%
For compound 4 the middle estimate is 30 percentage points below the measured one; the measured number lies above the stated range.
By their numbers in this assay, from the lowest: compounds 1, 2 and 3 (each within the scatter of the next); then compound 4.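

In this assay, among these compounds, the exchange of the group of 12 heavy atoms for (((iodomethyl)carbonyl)amino)methyl gives a number 30 percentage points higher from compound 1 to compound 4 (beyond the scatter), the first reading in the set to leave the level shared by the earlier compounds, so a change at this place on the chain can register in the read-out. Compound 1 and compound 4 both end in the iodoacetamide, so that end alone does not set the reading; what differs is the stretch leading to it, which is shorter in compound 4 and has lost one of the two amide groups of compound 1 along with its added atoms. No separate measurement bears on why the reading differs between these two compounds.

This single step cannot separate the shorter chain from the loss of that inner amide, since both change together. Also open, going by these compounds, is whether a plain alkyl chain shorter or longer than that of compound 4, an ether oxygen within the chain, or a chloroacetamide end in place of the iodoacetamide moves the reading further or returns it to the earlier level.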